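This account rests on a few compounds, and the source may have more. Where it says the series, first, only, none or still open, it means among the compounds named here.

Of the compounds shown here, three built on one shared core have been measured in a functional assay on SGC-7901 cells (Homo sapiens) for antiproliferative activity, read by sulforhodamine B assay, with a stated time of 72 h; a lower number here means a stronger inhibitor, a higher number a weaker inhibitor. Compound 1, `COc1cccc(NC(=S)N/N=C/c2ccc3ccccc3n2)c1`, gives 79400 nM. Compound 2, `Cc1ccc(NC(=O)N/N=C/c2ccc3ccccc3n2)cc1`, reaches only the limit of this assay, > 100000 nM, which is a boundary of the measurement rather than a number. Compound 3, `FC(F)(F)c1ccccc1NC(=S)N/N=C/c1ccc2ccccc2n1`, gives 20700 nM, the lower of the two numbers recorded, and its nearest neighbour among them is compound 1, whose number is higher by a margin beyond the usual scatter.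

Compound 4, `COc1ccccc1NC(=S)N/N=C/c1ccc2ccccc2n1`, has not yet been measured in this assay. It differs from compound 3 in one place: methoxy in place of trifluoromethyl on an aromatic carbon. Among the compounds with values here, the only other compound here with a methoxy on its outer ring is compound 1, whose value of 79400 nM sits well above that of compound 3, so the move from trifluoromethyl to methoxy is expected to carry the number upward in this assay by more than the scatter. Compound 4 is therefore estimated at 55000 nM, with a plausible range from 20000 nM to 100000 nM. The expected step is a 2.7-fold higher number from compound 3 to compound 4 (0.42 log units; beyond the scatter). There is also a fair chance that compound 4 only reaches the limit of this assay.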

Compound 4, half-maximal inhibitory concentration: > 100000 nM
Compound 4: a limit, no number; the forecaster's own chance of this, stated with the estimate: 30%; at least 1.8-fold (0.25 log units) between middle value and limit.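

Within the data shown here, this is the first comparison here between two compounds that differ in one place, and it shows that in this assay the outcome depends on which group sits on this aromatic carbon, ortho to a large group: trifluoromethyl gives way to methoxy with an at least 4.8-fold higher number from compound 3 to compound 4 (0.68 log units; beyond the scatter). Moving the methoxy on the outer ring, with 2-methoxyphenyl in place of 3-methoxyphenyl on an amide-type nitrogen, gives an at least 1.2-fold higher number from compound 1 to compound 4 (0.10 log units; that floor lies within the scatter), so these compounds do not separate the two methoxy placements. Both steps are floors rather than full sizes, because compound 4 stands at a limit and not at a number: the limit of > 100000 nM in this assay, at which 2 of the 4 values shown sit.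

On these data alone, it remains open whether the lower number of compound 3 is particular to trifluoromethyl or would also appear with other groups on this carbon, such as chlorine, an amine or a carboxylic acid. Also unresolved are how trifluoromethyl would behave on another carbon of the outer ring and what the carbonyl of compound 2 contributes, since no pair shown differs only at that atom.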